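Taking the amino group off compound 1

The source may hold more compounds than are shown below. What is called first, only, known or untested is meant among the compounds shown, and "the series" means these compounds.

Measured so far in an ADME assay on microsomes from liver (Homo sapiens) for metabolic stability, read by LC-MS, using NADPH, with a stated time of 10 min, tested at 10 uM; a higher number here means that the compound lasts longer, a lower number that the compound disappears faster:

- compound 1 `Nc1ncnc2c1c(Oc1cc(C(F)(F)F)ccn1)nn2[C@H]1CC[C@@H](N)CC1` gives > 2.41 h (a limit)
- compound 2 `N#Cc1ccnc(Oc2nn(C3CC3)c3ncnc(N)c23)c1` gives > 2.41 h (a limit)
- compound 3 `Nc1ncnc2c1c(Oc1cc(O)ccn1)nn2[C@H]1C[C@H](F)C1` gives 1.03 h (a number)

Compound 1 stands at the limit of > 2.41 h in this assay, at which 2 of the 3 values shown sit, and so has a limit and no exact number. Compound 4 `Nc1ncnc2c1c(Oc1cc(C(F)(F)F)ccn1)nn2C1CCCCC1` is not yet measured. It keeps the core of compound 1 but turns 4-aminocyclohexyl into cyclohexyl, with hydrogen in place of amino on a saturated ring carbon. Among the measured compounds shown here, no measured pair shows this change, so what follows is a judgement. A moderate fall beyond the scatter is expected, and the expected step is an at least 1.7-fold lower number from compound 1 to compound 4 (0.23 log units; that floor lies within the scatter) in size. For this assay compound 4 is estimated at 1.4 h within a range (0.5 h to 2.4 h).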

Compound 4, half-life: 0.55 h
Compound 4: middle estimate off by 2.5-fold (0.41 log units), on the high side, within the range that was stated.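

Among the compounds shown here, for the first time, a change in one place can be read in this assay: putting hydrogen in place of amino on the saturated ring carbon gives an at least 4.3-fold lower number from compound 1 to compound 4 (0.64 log units; beyond the scatter). This position therefore matters for how long the compound lasts, at least in this pair. The step is only a floor, because compound 1 carries a limit and no exact number: the limit of > 2.41 h in this assay, at which 2 of the 4 values shown sit.

From the compounds shown here alone, what a carboxylic acid or a methoxy group on this ring carbon would give stays open. So does whether the same change would act alike on compounds with another group on the shared core.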